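Replacing a Nitro Group with Methoxy on a Shared Core

The source may hold more compounds than are shown below. What is called first, only, known or untested is meant among the compounds shown, and "the series" means these compounds.

Of the compounds shown here, three built on one shared core have been tested in a functional assay on Jurkat cells (Homo sapiens) for antiproliferative activity, read by MTT assay, with a stated time of 72 h; a higher number here means a weaker inhibitor, a lower number a stronger inhibitor. Compound 1 `COc1cc(-n2ncnc2-c2cccc([N+](=O)[O-])c2)cc(OC)c1OC` carries a nitro group on one of its outer rings. In this assay compound 1 gives only > 10000 nM, which is a limit of the assay rather than a measured number. Compound 3 `COc1cc(-c2ncnn2-c2cccc([N+](=O)[O-])c2)cc(OC)c1OC` likewise reaches only the limit > 10000 nM in this assay. Compound 2 `COc1ccc(-n2ncnc2-c2cc(OC)c(OC)c(OC)c2)cc1`, whose outer rings carry only methoxy groups, gives 93 nM in this assay. Compound 1 therefore stands at the weak end of what has been seen so far, sharing the limit of > 10000 nM in this assay, at which 2 of the 3 values shown sit, with compound 3, while compound 2 is the only one of the three to give a number.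

Compound 4 `COc1cccc(-c2ncnn2-c2cc(OC)c(OC)c(OC)c2)c1` has not yet been measured. It differs from compound 1 in a single place: methoxy in place of nitro on an aromatic carbon. Among the measured compounds shown here, no measured pair shows exactly this change, so its size can only be judged against the three values already in hand, where both nitro-bearing compounds sit at the limit and only the methoxy-bearing compound 2 gives a number. Compound 4 is therefore expected to land at about 1000 nM, within a range from 100 nM to 10000 nM. The estimated step of an at least 10-fold lower number from compound 1 to compound 4 (1.00 log units; beyond the scatter) is expected to point toward stronger inhibition and to lie beyond the usual scatter.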

Compound 4, half-maximal inhibitory concentration: > 10000 nM
Compound 4: no number, only a limit (the forecaster's own chance of this, stated with the estimate: 30%); at least 10-fold (1.00 log units) between middle value and limit.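

In this assay compound 4 gives > 10000 nM as a limit of the assay and not as a number. Compound 1 also stands at a limit, and the step from compound 1 to compound 4 cannot be read. From the compounds shown here alone, what stays open is whether methoxy in place of nitro on an aromatic carbon changes the activity of compound 1 at all, and by how much.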